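The source may report more compounds than this note shows. Statements on the series, on what has been measured and on what is new or still open speak of the compounds shown alone.

Values so far in a physicochemical assay for lipophilicity; a higher number here means a more lipophilic compound, a lower number a more polar compound:

- compound 1 `COc1ccc(C(=O)N(Cc2[nH]ncc2-c2ccccc2)C2CCCCC2)cc1`: 3.1
- compound 2 `COc1ccc(C(=O)N(Cc2ccc(-c3ccc(Cl)cc3)o2)C2CCCCC2)cc1`: 5
- compound 3 `O=C(CN(CC1CC1)C(=O)c1ccc(-c2ccccn2)cc1)Nc1cc(F)cc(F)c1`: 3.1

Compound 3, at 3.1, stands level with compound 1, and together they hold the lowest number of the three. Compound 2, at 5, lies beyond the usual scatter above compound 3.

Compound 4 `O=C(CN(C(=O)c1ccc(-c2ccccn2)cc1)C1CCOCC1)Nc1cc(F)cc(F)c1` is not yet measured. It carries oxan-4-yl in place of cyclopropylmethyl on an amide-type nitrogen. The group that leaves contains only carbon, while the one that enters has an oxygen in its ring.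

Among the compounds with values here, no measured pair shows a change in one place, so the expectation rests on the structures and on compound 3 at 3.1. A modest fall in this assay is expected, small beside the gap up to compound 2 and probably just beyond the scatter. The expected step is a number 0.50 log units lower from compound 3 to compound 4 (beyond the scatter). Compound 4 is estimated at 2.6, with an expected range from 2.2 to 3.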

Compound 4, distribution coefficient: 2.5
For compound 4 the middle estimate is 0.10 log units above the measured one, within the range that was stated.
By their numbers in this assay, from the lowest: compound 4; then compounds 1 and 3 (each within the scatter of the next); then compound 2.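

In this assay, oxan-4-yl in place of cyclopropylmethyl on the amide-type nitrogen gives a number 0.60 log units lower from compound 3 to compound 4 (beyond the scatter), the first change in one place among these compounds. The number at this position therefore responds to the group it carries, even with the rest of the molecule unchanged, and compound 4 now sits lowest of the four. No measurement here gives a reason for this step.

The compounds shown leave open how much of the step goes with the ring oxygen and how much with the change in ring and group size, a question that a plain cyclohexyl group on the same nitrogen would help to separate. They also leave open how a piperidin-4-yl ring, which carries an amine, or a longer carbon chain would read at this place.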